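Bromo to chloro on compound 2

This account rests on a few compounds, and the source may have more. Where it says the series, first, only, none or still open, it means among the compounds named here.

Measured in a functional assay on HCT-116 cells (Homo sapiens) for antiproliferative activity, read by MTT assay, with a stated time of 72 h; a lower number here means a stronger inhibitor, a higher number a weaker inhibitor:
Compound 1 `COc1ccc(OCCCON2C(N)=NC(N)=NC23CCOCC3)cc1` gives 1500 nM
Compound 2 `NC1=NC2(CCSCC2)N(OCCCOc2ccc(Br)cc2)C(N)=N1` gives 20 nM
Compound 3 `NC1=NC2(CCOCC2)N(OCCCOc2ccccc2Cl)C(N)=N1` gives 70 nM

Among these three, compound 2 holds the lowest number, well under compound 3 and further still under compound 1. Compound 4 `NC1=NC2(CCSCC2)N(OCCCOc2ccc(Cl)cc2)C(N)=N1` differs from it in one place: chloro in place of bromo on an aromatic carbon, para to a large group. Going by the values given here, no measured pair makes this exchange. Among the compounds with values here, the only measured step is a 21-fold lower number from compound 1 to compound 3 (1.33 log units; beyond the scatter), which is large but puts 2-chlorophenyl in place of 4-methoxyphenyl, a different change, so it says little here. Only a small shift is therefore expected: the estimated step is a 1.3-fold higher number from compound 2 to compound 4 (0.10 log units; within the scatter), which stays within the scatter in this assay. For compound 4 the estimated value is 25 nM, with an expected range from 10 nM to 70 nM.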

Compound 4, half-maximal inhibitory concentration: 10 nM
Compound 4: middle estimate off by 2.5-fold (0.40 log units), on the high side, within the range that was stated.
By their numbers in this assay, from the lowest: compounds 4 and 2 (each within the scatter of the next); then compound 3; then compound 1.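

In this assay chloro in place of bromo on an aromatic carbon, para to a large group, gives a 2.0-fold lower number from compound 2 to compound 4 (0.30 log units; within the scatter) and so this position takes either halogen without a step beyond the scatter. The earlier step changed the whole aryl group and could not show this exchange alone. Nothing available explains the result. Still open, as far as these compounds go, is whether fluoro, methyl or an amine at this position would read like these two halogens. Also open, from the compounds shown here alone, is whether the exchange would read the same on the core of compound 3.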